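Aryl Replacement at the Ortho Position of a TRPV1 Antagonist Series

A few compounds are considered here, and "the series" means these few. Any claim that something is new, unique, unknown or untested is made for them only; others in the source may bear on it.

Measured compounds:
compound 1 `CC1CCN(c2cc(C(F)(F)F)ccc2CNC(=O)C(C)c2ccc(NS(C)(=O)=O)c(F)c2)CC1`, 0.9 nM;
compound 2 `CC(C)CCSc1cc(C(F)(F)F)ccc1CNC(=O)C(C)c1ccc(NS(C)(=O)=O)c(F)c1`, 1.4 nM.

In an assay on CHO cells for antagonist activity at transient receptor potential cation channel subfamily V member 1 (Homo sapiens), read by FLIPR (on this read-out higher numbers stand for weaker inhibition and lower numbers for stronger inhibition), compound 2 gives the higher of the two numbers, yet the step of a 1.6-fold higher number from compound 1 to compound 2 (0.19 log units; within the scatter) lies within the scatter, so the two compounds cannot be ordered. Compound 3 `CC(C(=O)NCc1ccc(C(F)(F)F)cc1-c1cccc(F)c1)c1ccc(NS(C)(=O)=O)c(F)c1` differs from compound 2 by 3-fluorophenyl in place of isopentylsulfanyl on an aromatic carbon. Among the measured compounds shown here, the only measured step at this position, a 1.6-fold higher number from compound 1 to compound 2 (0.19 log units; within the scatter), changed little, and no other step bears on an aromatic substituent here. Compound 3 is therefore expected to show no step beyond the scatter, a 1.4-fold higher number from compound 2 to compound 3 (0.15 log units; within the scatter). The estimate for compound 3 is 2 nM, between 0.6 nM and 7 nM.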

Compound 3, inhibition constant: 1.9 nM
Estimate against measurement, compound 3: 1.1-fold (0.02 log units) above; the range from low to high includes it.
By their numbers in this assay, from the lowest: compounds 1, 2 and 3 (each within the scatter of the next, the first and the last beyond it).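

In this assay a ring is tolerated here as well as a chain: replacing isopentylsulfanyl with 3-fluorophenyl gives a 1.4-fold higher number from compound 2 to compound 3 (0.13 log units; within the scatter) and so leaves the two groups unordered. Among the compounds shown here, replacing 4-methylpiperidin-1-yl with the same ring gives a 2.1-fold higher number from compound 1 to compound 3 (0.32 log units; beyond the scatter) and is the first step at this position to pass the scatter, though only modestly. No evidence is available to explain these results. Still open, on these data alone, is how a phenyl without fluorine, a primary amine or a carboxylic acid would fare at this position.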